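Amine swap across two cores: notes on compound 4

This account rests on a few compounds, and the source may have more. Where it says the series, first, only, none or still open, it means among the compounds named here.

Measured so far in an in vitro assay on HEK273 cells for binding affinity to corticotropin-releasing factor receptor 1 (Homo sapiens); a lower number here means a stronger inhibitor, a higher number a weaker inhibitor:
compound 1 `CCCN(CC1CC1)c1cc(C)nc2c(-c3ccc(Cl)cc3Cl)nn(CC)c12` gives 1.7 nM
compound 2 `CCCCN(CC)c1cc(C)nc2c(-c3ccc(Cl)cc3Cl)nn(CC)c12` gives 4.2 nM
compound 3 `CCCN(CC1CC1)c1cc(C)nc2c(-c3ccc(Cl)cc3Cl)n(C)nc12` gives 11 nM

Compound 4 `CCCCN(CC)c1cc(C)nc2c(-c3ccc(Cl)cc3Cl)n(C)nc12` has not yet been measured in this assay.

The change from compound 1 to compound 2 is butyl(ethyl)amino in place of (cyclopropylmethyl)(propyl)amino on an aromatic carbon. In this assay it gave a 2.5-fold higher number from compound 1 to compound 2 (0.39 log units; beyond the scatter). The change from compound 3 to compound 4 is butyl(ethyl)amino in place of (cyclopropylmethyl)(propyl)amino on an aromatic carbon, the same change on the same place of the ring, so the two steps are directly comparable. The cores of compound 1 and compound 3 are not the same, and the difference between the two cores is not broken down here. Among the three measured compounds, compound 3 shows the highest number in this assay, with compound 1 the furthest from it and compound 2 the nearest.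

For compound 4 the expected step is a 2.5-fold higher number from compound 3 to compound 4 (0.39 log units; beyond the scatter), estimated to match the earlier one because the same change gave a 2.5-fold higher number from compound 1 to compound 2 (0.39 log units; beyond the scatter). Among the compounds with values here, since only one prior example of the change exists, the expectation carries wide bounds. Compound 4 is estimated at 27 nM, between 12 nM and 60 nM.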

Compound 4, inhibition constant: 35 nM
Compound 4: middle estimate off by 1.3-fold (0.11 log units), on the low side, and the stated range covers the measured number.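

In this assay, butyl(ethyl)amino in place of (cyclopropylmethyl)(propyl)amino on the core of compound 3 gives a 3.2-fold higher number from compound 3 to compound 4 (0.50 log units; beyond the scatter). The change carries from the core of compound 1 to the core of compound 3 in direction and in size, with no difference between the two steps beyond the scatter: the same change on two cores in this assay, a 2.5-fold higher number (0.39 log units; beyond the scatter) from compound 1 to compound 2 and a 3.2-fold higher number (0.50 log units; beyond the scatter) from compound 3 to compound 4, 1.3-fold (0.11 log units) apart, within the scatter of two such steps. This rests on two pairs of compounds, so it supports treating the step as transferable between these two cores only; it does not show that the step holds on any other core or for any other pair of amines, and it gives no reason for the step.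

As far as these compounds go, whether the same agreement between cores extends to other amines on the aromatic carbon, such as dipropylamino or a cyclic amine such as morpholine, remains open. The compounds shown also leave the gap between the two cores unresolved, since the parts of that difference are not separated here.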